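Notes on a naphthalen-1-yl replacement in the series

The source may report more compounds than this note shows. Statements on the series, on what has been measured and on what is new or still open speak of the compounds shown alone.

compound 1, `COc1ccccc1/C=C/C(=O)/C=C/c1ccc(OCc2cn(CCOc3cc(=O)oc4ccccc34)nn2)c(OC)c1`: 7330 nM in a functional assay on THP-1 cells (Homo sapiens) for cytotoxicity, read by sulforhodamine B assay, with a stated time of 48 h; a higher number here means a weaker inhibitor, a lower number a stronger inhibitor
compound 2, `COc1ccc(/C=C/C(=O)/C=C/c2ccc(OCc3cn(CCOc4cc(=O)oc5ccccc45)nn3)c(OC)c2)cc1OC`: 2340 nM
compound 3, `COc1ccc(/C=C/C(=O)/C=C/c2ccc(OCc3cn(CCOc4cc(=O)oc5ccccc45)nn3)c(OC)c2)cc1`: 7410 nM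

Compound 3 gives the highest number of the three in this assay, but its gap to compound 1 is within the scatter; only compound 2 stands clearly apart, as the step of a 3.2-fold higher number from compound 2 to compound 3 (0.50 log units; beyond the scatter) shows. Compound 4, `COc1cc(/C=C/C(=O)/C=C/c2cccc3ccccc23)ccc1OCc1cn(CCOc2cc(=O)oc3ccccc23)nn1`, differs from compound 3 in one place: naphthalen-1-yl in place of 4-methoxyphenyl on a double-bonded chain carbon bound to a double-bonded chain carbon. Within the data shown here, none of the measured steps swaps a phenyl for a naphthalen-1-yl; the steps of a 3.1-fold lower number from compound 1 to compound 2 (0.50 log units; beyond the scatter) and a 1.0-fold higher number from compound 1 to compound 3 (0.00 log units; within the scatter) involve only methoxy groups on the shared core, so they bear on this change only loosely. Those moves reached at most a modest size and set no direction, so for compound 4 a change within the scatter is expected, a 1.2-fold lower number from compound 3 to compound 4 (0.09 log units; within the scatter). Compound 4 is estimated at 6000 nM, with a range from 2000 nM to 18000 nM.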

Compound 4, half-maximal inhibitory concentration: 4480 nM
Compound 4: middle estimate off by 1.3-fold (0.13 log units), on the high side, and the stated range covers the measured number.
By their numbers in this assay, from the lowest: compounds 2, 4, 1 and 3 (each within the scatter of the next, the first and the last beyond it).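

In this assay, naphthalen-1-yl on a double-bonded chain carbon bound to a double-bonded chain carbon gives no step beyond the scatter against any of the three methoxy-bearing groups (a 1.7-fold lower number from compound 3 to compound 4 (0.22 log units; within the scatter); a 1.6-fold lower number from compound 1 to compound 4 (0.21 log units; within the scatter); a 1.9-fold higher number from compound 2 to compound 4 (0.28 log units; within the scatter)). Compound 4 is the only compound shown with no oxygen in the group at this place, and a methoxy group on a phenyl ring is therefore not needed there to stay within the scatter of these compounds. No measurement shown accounts for this result.

Still open, from the compounds shown here alone, is whether naphthalen-2-yl, or a phenyl ring carrying an amine or a carboxylic acid, would move the number beyond the scatter at this place.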